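The source may hold more compounds than are shown below. What is called first, only, known or untested is meant among the compounds shown, and "the series" means these compounds.

Measured compounds:
- compound 1, `Cn1c(=O)c2c(nc(SCCc3ccc(Br)cc3)n2C)n(C)c1=O`, gives 108000 nM in an assay on microsomes for inhibition of Amine oxidase [flavin-containing] A (Homo sapiens), read by fluorescence and spectrophotometry, with a stated time of 20 min; a lower number here means a stronger inhibitor, a higher number a weaker inhibitor
- compound 2, `Cn1c(=O)c2c(nc(SCCc3ccc(F)cc3)n2C)n(C)c1=O`, gives 14700 nM in this assay
- compound 3, `Cn1c(=O)c2c(nc(SCCc3cccc(Br)c3)n2C)n(C)c1=O`, gives 5700 nM in this assay

Compound 3 stands lowest of the three numbers in this assay: compound 2 comes nearest, and compound 1 lies furthest away. The two steps that reach compound 3 are both beyond the scatter: a 19-fold lower number from compound 1 to compound 3 (1.28 log units; beyond the scatter) and a 2.6-fold lower number from compound 2 to compound 3 (0.41 log units; beyond the scatter). The third step, a 7.3-fold lower number from compound 1 to compound 2 (0.87 log units; beyond the scatter), shows that exchanging one halogen for another on the ring also moves the number.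

Compound 4, `COc1cccc(CCSc2nc3c(c(=O)n(C)c(=O)n3C)n2C)c1`, is still to be measured. It differs from compound 3 by methoxy in place of bromo on an aromatic carbon. No measured step exchanges bromo for methoxy, and none changes anything at the 3-position of the ring, so the direction of this step is not shown by the data. Going by the values given here, the only guide is compound 1 to compound 2, where swapping one halogen for another on the same ring gave a modest step, so a step of similar size in either direction is plausible. Compound 4 is therefore expected to land close to compound 3, with a 1.4-fold higher number from compound 3 to compound 4 (0.15 log units; within the scatter) as the estimated step, giving an expected value of 8000 nM, within a range from 2000 nM to 32000 nM.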

Compound 4, half-maximal inhibitory concentration: 48100 nM
For compound 4 the middle estimate is 6.0-fold (0.78 log units) below the measured one, and the stated range ends below it.
By their numbers in this assay, from the lowest: compound 3; then compound 2; then compound 4; then compound 1.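

In this assay, keeping the substituent at the same ring place but putting methoxy in place of bromo still moves the number (an 8.4-fold higher number from compound 3 to compound 4 (0.93 log units; beyond the scatter)), so the group itself matters here, not only where it sits. The 3-methoxyphenyl compound also lands between the two 4-substituted compounds (a 3.3-fold higher number from compound 2 to compound 4 (0.51 log units; beyond the scatter); a 2.2-fold lower number from compound 1 to compound 4 (0.35 log units; beyond the scatter)), so among these compounds, a substituent at this ring place does not by itself give the lowest number. Nothing available here explains why the exchange of bromo for methoxy shifts the number.

With only bromo and methoxy at this ring place, no trend across groups can be drawn. From the compounds shown here alone, whether chloro, an amine or a carboxylic acid there would give a lower or a higher number remains open, as does the effect of a longer chain between the sulfur and the ring.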